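A New Side Group for Compound 2

The source may hold more compounds than are shown below. What is called first, only, known or untested is meant among the compounds shown, and "the series" means these compounds.

Compound 1 `CCOc1ccc(NC(=O)c2ccc(C(CC)(CC)c3ccc(OCCC(O)(CC)CC)c(C)c3)n2CC)cc1` and compound 2 `CCOC(=O)C(CC(=O)OC)NC(=O)c1ccc(C(CC)(CC)c2ccc(OCCC(O)(CC)CC)c(C)c2)n1CC` share a core and differ in the group on an amide-type nitrogen. In a functional assay on PC-3 cells (Homo sapiens) for antiproliferative activity, read by MTT assay, with a stated time of 48 h (a lower number here means a stronger inhibitor, a higher number a weaker inhibitor), compound 1 gives > 50000 nM as a limit of the assay, not a number. Going by the values given here, compound 2 gives 5840 nM and so holds the only true number so far. Compound 3 `CCC(C)C(NC(=O)c1ccc(C(CC)(CC)c2ccc(OCCC(O)(CC)CC)c(C)c2)n1CC)C(=O)O` changes that same place again, where a group of 8 heavy atoms (6 carbon, 2 oxygen; no ring) in place of a group of 11 heavy atoms (7 carbon, 4 oxygen; no ring), on an amide-type nitrogen brings in 1-carboxy-2-methylbutyl. Among the compounds with values here, the only measured step bearing on this, an at least 8.5-fold lower number from compound 1 to compound 2 (0.93 log units; beyond the scatter), replaced a group holding a ring with one that has none. Neither group in the new change has a ring, so that step is a weak guide, and no shift beyond the scatter is expected. The estimated step is a 1.2-fold higher number from compound 2 to compound 3 (0.08 log units; within the scatter) in this assay, though with wide uncertainty. For compound 3 the estimate is 7000 nM, with an expected range from 2000 nM to 25000 nM.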

Compound 3, half-maximal inhibitory concentration: 13800 nM
The estimate for compound 3 lay 2.0-fold (0.29 log units) below the measured number, within the range that was stated.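

The position on the amide-type nitrogen still responds when no ring is involved: in this assay, swapping one ring-free group for another gives a 2.4-fold higher number from compound 2 to compound 3 (0.37 log units; beyond the scatter), so the earlier ring-for-no-ring step did not tell the whole story. The second ring-free group, 1-carboxy-2-methylbutyl, also compares well with 4-ethoxyphenyl, with an at least 3.6-fold lower number from compound 1 to compound 3 (0.55 log units; beyond the scatter), and so both ring-free groups shown give lower numbers than the ring-bearing one. That comparison is only a bound, since compound 1 holds a limit and not a true number: the limit of > 50000 nM in this assay, at which 1 of the 3 values shown sits.

The groups in compound 2 and compound 3 differ in size and in their hydrogen-bond donors and acceptors all at once, so these compounds cannot show which difference matters. Going by these compounds, it also remains open how a plain 2-methylbutyl chain, without the carboxylic acid, would behave at this position.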